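The source may report more compounds than this note shows. Statements on the series, on what has been measured and on what is new or still open speak of the compounds shown alone.

In a functional assay on HeLa cells (Homo sapiens) for inhibition, read by sulforhodamine B assay (a higher number here means a weaker inhibitor, a lower number a stronger inhibitor), three compounds of this series have been measured:

Compound 1, `O=C1C=C(NCc2ccccc2)C(=O)c2c1nc1n2[C@H]2OC[C@@H](O)[C@H]2OC1`: > 8000 nM
Compound 2, `O=C1C=C(Nc2ccccc2)C(=O)c2c1nc1n2[C@H]2OC[C@@H](O)[C@H]2OC1`: 5620 nM
Compound 3, `CCOc1ccc(NC2=CC(=O)c3nc4n(c3C2=O)[C@H]2OC[C@@H](O)[C@H]2OC4)cc1`: 3110 nM

The value of compound 1 is a limit of this assay, not a number (the limit of > 8000 nM in this assay, at which 1 of the 3 values shown sits). Compound 2 carries phenyl in place of benzyl on the amine nitrogen, and the result is an at least 1.4-fold lower number from compound 1 to compound 2 (0.15 log units; that floor lies within the scatter). Compound 3 carries 4-ethoxyphenyl in that place, giving an at least 2.5-fold lower number from compound 1 to compound 3 (0.41 log units; beyond the scatter). Between the two numbered compounds the step is a 1.8-fold lower number from compound 2 to compound 3 (0.26 log units; within the scatter), so compound 3 holds the lower of the two numbers, but not by a margin that sets it apart from compound 2.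

Compound 4, `O=C1C=C(Nc2ccc(Br)cc2)C(=O)c2c1nc1n2[C@H]2OC[C@@H](O)[C@H]2OC1`, differs from compound 3 by bromo in place of ethoxy on an aromatic carbon. For the measured compounds named here, the only measured step at this position is the one from compound 2 to compound 3, which stayed within the scatter; no step with a bromo group has been measured. Compound 4 is therefore expected to sit close to compound 3, with a 1.1-fold higher number from compound 3 to compound 4 (0.05 log units; within the scatter) the estimated step, and the expected value for compound 4 in this assay is 3500 nM, in the range 1500 nM to 9000 nM.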

Compound 4, half-maximal inhibitory concentration: 3830 nM
Compound 4: middle estimate off by 1.1-fold (0.04 log units), on the low side; measured number inside the range.
By their numbers in this assay, from the lowest: compounds 3, 4 and 2 (each within the scatter of the next). At a limit, above all of these: compound 1.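

In this assay, this position accepts two very different replacements without a change beyond the scatter: bromo, a single bromine atom, in place of the three heavy atoms of ethoxy gives a 1.2-fold higher number from compound 3 to compound 4 (0.09 log units; within the scatter), and bromo in place of hydrogen gives a 1.5-fold lower number from compound 2 to compound 4 (0.17 log units; within the scatter). With 4-bromophenyl in place of benzyl on the amine nitrogen, the result is an at least 2.0-fold lower number from compound 1 to compound 4 (0.31 log units; beyond the scatter), so a second substituted phenyl group now shows a step beyond the scatter against the benzyl compound. The value of compound 1 is a limit, not a number: the limit of > 8000 nM in this assay, at which 1 of the 4 values shown sits.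

As far as these compounds go, what an amine or a carboxylic acid on this aromatic carbon would do remains open. So does whether any group there can separate a compound from compound 2 by more than the scatter.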